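Compound 3 and its methyl ester, compound 4

The compounds below may be only part of what the source reports. "The series", "measured", "known", "first", "only" and "open" are said of these compounds alone.

Measured in a functional assay on SK-OV-3 cells (Homo sapiens) for inhibition, read by CCK-8 assay, with a stated time of 70 h; a lower number here means a stronger inhibitor, a higher number a weaker inhibitor:

Compound 1 (`c1ccc(COc2ccc(OCCOCCNc3ccccc3)cc2)cc1`) : > 100000 nM
Compound 2 (`c1ccc(COc2ccc(COc3ccc(OCCOCCNC4CCCCC4)cc3)cc2)cc1`) : 8080 nM
Compound 3 (`O=C(O)c1ccccc1COc1ccc(OCCOCCNC2CCCC2)cc1`) : > 100000 nM

In this assay compound 3 gives > 100000 nM, which is a limit of the assay and not a number. Compound 1 gives > 100000 nM, which is also a limit. Compound 3 therefore stands at the limit of > 100000 nM in this assay, at which 2 of the 3 values shown sit. Within the data shown here, the only true number in the set belongs to compound 2, at 8080 nM.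

The next compound to be tested is compound 4 (`COC(=O)c1ccccc1COc1ccc(OCCOCCNC2CCCC2)cc1`). It departs from compound 3 at a single place, and the change is methyl in place of hydrogen on an oxygen next to a carbonyl group. In other words, carboxy gives way to methoxycarbonyl, and 2-carboxyphenyl becomes 2-(methoxycarbonyl)phenyl.

Among the measured compounds shown here, no measured pair isolates this change, so its size in this assay can only be judged loosely. Compound 3 has only a limit, which leaves stronger inhibition as the one direction in which a change could be read. Compound 2 at 8080 nM shows that a measurable number is possible among these compounds. The expected change is modest and towards stronger inhibition, and it is estimated as an at least 2.5-fold lower number from compound 3 to compound 4 (0.39 log units; beyond the scatter). A second limit remains quite possible. For compound 4 the expected value is 40000 nM, with an estimated range from 10000 nM to 100000 nM.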

Compound 4, half-maximal inhibitory concentration: > 100000 nM
Compound 4 gave a limit, no number; the forecaster's own chance of this, stated with the estimate: 40%; middle value at least 2.5-fold (0.39 log units) away from the limit.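

In this assay compound 4 gives > 100000 nM which is a limit of the assay and not a number. Compound 3 also gave only a limit, so the step from compound 3 to compound 4 cannot be read: the limit of > 100000 nM in this assay, at which 3 of the 4 values shown sit. Going by these compounds, whether methyl in place of hydrogen on an oxygen next to a carbonyl group alters inhibition in this assay remains open.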